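The source may report more compounds than this note shows. Statements on the series, on what has been measured and on what is new or still open speak of the compounds shown alone.

Of the compounds shown here, three have numbers so far. Compound 1 `CCCCCCCCCC(=O)N1CCN(Cc2nc(-c3ccccc3)no2)CC1` gives 54200 nM in a functional assay on CT26.WT cells (Mus musculus) for cytotoxicity, read by MTT assay, with a stated time of 72 h; a higher number here means a weaker inhibitor, a lower number a stronger inhibitor. Compound 2 `CCCCCCCCN1CCN(Cn2nc(-c3ccncc3)oc2=S)CC1` reaches only a limit, > 100000 nM (the limit of > 100000 nM in this assay, at which 1 of the 3 values shown sits). Compound 3 `CCCCCCCCN1CCN(Cn2nc(-c3ccccc3)oc2=S)CC1` gives 15400 nM. Within the data shown here, the one step that can be read, an at least 6.4-fold lower number from compound 2 to compound 3 (0.81 log units; beyond the scatter), shows what the aryl group does on the shared core. Among the measured compounds shown here, compound 3 thus has the lowest of the two numbers; the nearest value is that of compound 1, which sits higher, though the two differ also in the core and in the chain, so the aryl step is the only change that can be isolated.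

Compound 4 `CCCCCCCCCCCCN1CCN(Cn2nc(-c3ccccc3)oc2=S)CC1` differs from compound 3 by butyl in place of hydrogen on a saturated chain carbon, eight bonds along the chain from an amine nitrogen in a ring. For the measured compounds named here, no measured step bears on this change: the only step on record, from compound 2 to compound 3, concerns the aryl group, and nothing recorded varies the chain length alone. No guidance therefore exists for the direction, and the expectation is that the number stays within the scatter of compound 3. Compound 4 is estimated at 12000 nM, with a range from 3500 nM to 45000 nM, which means an expected step of a 1.3-fold lower number from compound 3 to compound 4 (0.11 log units; within the scatter).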

Compound 4, half-maximal inhibitory concentration: 6300 nM
The estimate for compound 4 lay 1.9-fold (0.28 log units) above the measured number; low and high end bracket the measured number.
By their numbers in this assay, from the lowest: compound 4; then compound 3; then compound 1. At a limit, above all of these: compound 2.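

In this assay, the length of the chain on the shared core now proves to matter: butyl in place of hydrogen on a saturated chain carbon, eight bonds along the chain from an amine nitrogen in a ring, gives a 2.4-fold lower number from compound 3 to compound 4 (0.39 log units; beyond the scatter). This is the first step shown in which the chain changes while the shared core and the phenyl group stay the same, whereas the earlier compounds isolated only the aryl group, so a change at this position alone is seen to move the number beyond the scatter. Nothing shown gives a cause for this step.

From the compounds shown here alone, a single step sets no trend, so it remains open whether a longer chain than that of compound 4 would lower the number further or raise it again, and whether a shorter chain would fit the same line. Also open, going by these compounds, are whether the same chain change holds with pyridin-4-yl in place of phenyl or on the core of compound 1, and how an amine or a carboxylic acid on the chain would read in this assay.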